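The source may report more compounds than this note shows. Statements on the series, on what has been measured and on what is new or still open speak of the compounds shown alone.

Three compounds have been measured in a functional assay on MCF7 cells (Homo sapiens) for cytotoxicity, read by sulforhodamine B assay, with a stated time of 48 h; on this read-out higher numbers stand for weaker inhibition of growth and lower numbers for stronger inhibition of growth:

compound 1 `O=C1C(=O)N(CN2CCN(c3ccnc4cc(C(F)(F)F)ccc34)CC2)c2cc(Cl)ccc21`, 15800 nM
compound 2 `O=C1C(=O)N(CN2CCN(c3ccnc4cc(C(F)(F)F)ccc34)CC2)c2cc(Br)ccc21`, 28100 nM
compound 3 `NC(=S)N/N=C1/C(=O)N(CN2CCN(c3ccnc4cc(C(F)(F)F)ccc34)CC2)c2cccc(Cl)c21`, 21600 nM

Compound 2 differs from compound 1 by bromo in place of chloro on an aromatic carbon. That change gave a 1.8-fold higher number from compound 1 to compound 2 (0.25 log units; within the scatter). Compound 3 has a different core from compound 1; the difference between the two cores is not broken down here. In this assay compound 3 stands close to compound 2 and to compound 1, and all three values lie within the scatter of one another.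

Compound 4 `NC(=S)N/N=C1/C(=O)N(CN2CCN(c3ccnc4cc(C(F)(F)F)ccc34)CC2)c2cccc(Br)c21` has not yet been measured. It differs from compound 3 by bromo in place of chloro on an aromatic carbon. This is the same kind of change as that from compound 1 to compound 2, but the surroundings differ: in compound 2 the bromo sits meta to a fused ring and para to a fused ring, whereas in compound 4 it sits ortho to a fused ring and meta to a fused ring. Because a 1.8-fold higher number from compound 1 to compound 2 (0.25 log units; within the scatter) stayed within the scatter, compound 4 is expected to show a step of about a 1.4-fold higher number from compound 3 to compound 4 (0.14 log units; within the scatter) in this assay. Compound 4 is therefore estimated at 30000 nM, with a plausible range from 12000 nM to 70000 nM.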

Compound 4, concentration for 50% growth inhibition: 50600 nM
Estimate against measurement, compound 4: 1.7-fold (0.23 log units) below, within the range that was stated.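

In this assay, bromo in place of chloro on an aromatic carbon gave a 2.3-fold higher number from compound 3 to compound 4 (0.37 log units; beyond the scatter), a modest step towards weaker inhibition of growth. Set beside the same change on the other core, the two steps cannot be told apart: the same change on two cores in this assay, a 1.8-fold higher number (0.25 log units; within the scatter) from compound 1 to compound 2 and a 2.3-fold higher number (0.37 log units; beyond the scatter) from compound 3 to compound 4, 1.3-fold (0.12 log units) apart, within the scatter of two such steps. Going by these compounds alone, the change therefore carried from one core to the other with the same direction and a comparable size, but this rests on only two pairs, one of which stayed within the scatter, and the halogen sits in a different place on each core, so the data cannot separate the influence of the core from that of position or show that the trend would hold on a further core.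

The compounds shown carry only chloro or bromo on this ring, which leaves open how fluoro, methoxy or an amine on the same aromatic carbon would compare. Going by these compounds, it also remains open where the parent with hydrogen at that carbon would stand relative to these halogen compounds.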